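Ethyl to 4-Chlorophenyl on the Amide Carbonyl

The source may hold more compounds than are shown below. What is called first, only, known or untested is meant among the compounds shown, and "the series" means these compounds.

Compound 1 `CCC(=O)Nc1c(C(O)(C(F)(F)F)C(F)(F)F)ccc2ccccc12` gives 8.91 nM in a functional assay (Sus scrofa) with sulfonylurea receptors; K-ATP channels (Homo sapiens) as the target (a higher number here means that more compound is needed for the effect, a lower number that less compound is needed), the lowest of the three numbers measured. Compound 2 `O=C(Nc1c(C(O)(C(F)(F)F)C(F)(F)F)ccc2ccccc12)C1CCC1` gives 81.3 nM, and compound 3 `O=C(Nc1c(C(O)(C(F)(F)F)C(F)(F)F)ccc2ccccc12)c1cccc([N+](=O)[O-])c1` gives 427 nM. Compound 4 `O=C(Nc1c(C(O)(C(F)(F)F)C(F)(F)F)ccc2ccccc12)c1ccc(Cl)cc1` has not yet been measured; it differs from compound 1 by 4-chlorophenyl in place of ethyl on a carbonyl carbon. For the measured compounds named here, two measured steps bear on this change: replacing ethyl with cyclobutyl, a 9.1-fold higher number from compound 1 to compound 2 (0.96 log units; beyond the scatter), and replacing ethyl with 3-nitrophenyl, a 48-fold higher number from compound 1 to compound 3 (1.68 log units; beyond the scatter). Both changes on the carbonyl carbon raised the number, the aromatic one more. Because a 48-fold higher number from compound 1 to compound 3 (1.68 log units; beyond the scatter) is large and 4-chlorophenyl is also a six-membered aromatic ring of carbon only, compound 4 is expected to show a large rise, a 20-fold higher number from compound 1 to compound 4 (1.31 log units; beyond the scatter). Compound 4 is therefore estimated at 180 nM, with a range from 60 nM to 600 nM.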

Compound 4, half-maximal effective concentration: 389 nM
Estimate against measurement, compound 4: 2.2-fold (0.33 log units) below, within the range that was stated.
By their numbers in this assay, from the lowest: compound 1; then compound 2; then compounds 4 and 3 (each within the scatter of the next).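

Compound 4 shows that the large rise does not belong to the 3-nitrophenyl group alone: there is a 44-fold higher number from compound 1 to compound 4 (1.64 log units; beyond the scatter) while the two aromatic groups stay level, with a 1.1-fold lower number from compound 3 to compound 4 (0.04 log units; within the scatter) at this carbonyl carbon. Against the cyclobutyl group, 4-chlorophenyl still gives a 4.8-fold higher number from compound 2 to compound 4 (0.68 log units; beyond the scatter) so both aromatic rings lie above this non-aromatic ring. Nothing measured here says why the number rises.

Going by these compounds, it remains open whether a longer chain such as butyl in place of ethyl, or a phenyl ring carrying an amine, would keep the number close to that of compound 1.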